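The compounds below may be only part of what the source reports. "The series", "measured", "known", "first", "only" and "open" are said of these compounds alone.

Measured in a functional assay on HL-60 cells (Homo sapiens) for inhibition, with a stated time of 72 h; on this read-out lower numbers stand for stronger inhibition and higher numbers for weaker inhibition:
Compound 1 `OC[C@H]1O[C@@H](n2cnc3c(COc4ccccn4)ncnc32)[C@H](O)[C@@H]1O`: 12000 nM
Compound 2 `CSCc1ncnc2c1ncn2[C@@H]1O[C@H](CO)[C@@H](O)[C@H]1O`: 13400 nM

Within the data shown here, only these two compounds have numbers so far, and the numbers do not separate them. Compound 2, at 13400 nM, stands level with compound 1, the gap being a 1.1-fold higher number from compound 1 to compound 2 (0.05 log units; within the scatter).

The next compound, compound 3 `CC(C)N(Cc1ncnc2c1ncn2[C@@H]1O[C@H](CO)[C@@H](O)[C@H]1O)C(C)C`, keeps the shared core and changes one group: diisopropylamino in place of methylsulfanyl on a saturated chain carbon bound to an aromatic carbon, (diisopropylamino in place of methylsulfanyl on a saturated chain carbon bound to an aromatic carbon).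

Just one measured step bears on this change, the one at the same place, where methylsulfanyl took the place of (pyridin-2-yl)oxy: a 1.1-fold higher number from compound 1 to compound 2 (0.05 log units; within the scatter). Among the measured compounds shown here, that is thin evidence, since no compound with diisopropylamino at this place has been measured. In this assay no step beyond the scatter is therefore expected, and no direction can be argued, although the margin has to stay wide. The expected change is a 1.1-fold lower number from compound 2 to compound 3 (0.05 log units; within the scatter). Compound 3 is expected at about 12000 nM, with an estimated range of 4000 nM to 35000 nM.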

Compound 3, half-maximal inhibitory concentration: 13000 nM
Compound 3: the middle estimate sits 1.1-fold (0.03 log units) below what was measured; the range from low to high includes it.
By their numbers in this assay, from the lowest: compounds 1, 3 and 2 (each within the scatter of the next).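

In this assay, putting diisopropylamino in place of methylsulfanyl on a saturated chain carbon bound to an aromatic carbon brings in 7 heavy atoms where 2 stood, yet the read-out stays level, with a 1.0-fold lower number from compound 2 to compound 3 (0.01 log units; within the scatter). The comparison with the (pyridin-2-yl)oxy group gives the same picture, with a 1.1-fold higher number from compound 1 to compound 3 (0.03 log units; within the scatter), so this position has now taken groups attached through oxygen, sulfur and nitrogen, including a branched amine, without any separation among the three compounds. The data at hand offer no explanation for why the number stays level across these groups.

Going by these compounds, it remains open whether any group on this carbon can move the number beyond the scatter in either direction, for example a carboxylic acid, a primary amine or a longer alkyl chain. All three compounds also keep the shared core unchanged, so what a change elsewhere in the molecule would do to this level of inhibition, and whether it would make this position matter, is still an open question.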